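The compounds below may be only part of what the source reports. "The series", "measured", "known", "first", "only" and "open" are said of these compounds alone.

In a functional assay on VCaP cells (Homo sapiens) for antiproliferative activity, read by CCK-8 assay, with a stated time of 6 days (on this read-out lower numbers stand for stronger inhibition and higher numbers for weaker inhibition), compound 1 `CCN(c1ccc(C#N)c(Cl)c1)c1cc(-c2ccncc2)ccc1C` gives 2900 nM and compound 3 `CCN(c1ccc(C#N)c(Cl)c1)c1cc(-c2cncnc2)ccc1C` gives 3920 nM, so compound 3 stands level with compound 1: a 1.4-fold higher number from compound 1 to compound 3 (0.13 log units; within the scatter). Compound 2 `CCN(c1ccc(C#N)c(Cl)c1)c1cc(-c2ccco2)ccc1C` reports only a limit, > 30000 nM. Next is compound 4 `CCN(c1ccc(C#N)c(Cl)c1)c1cc(-c2ccnn2C)ccc1C`, with 1-methyl-1H-pyrazol-5-yl in place of pyrimidin-5-yl on an aromatic carbon. The closest guide is furan-2-yl, the only five-membered aromatic ring measured so far, which costs much: an at least 10-fold higher number from compound 1 to compound 2 (1.01 log units; beyond the scatter), and an at least 7.6-fold lower number from compound 2 to compound 3 (0.88 log units; beyond the scatter). Compound 4 shares that ring size but keeps two ring nitrogens, so only part of that loss is expected. For compound 4 the estimated step is a 2.0-fold higher number from compound 3 to compound 4 (0.31 log units; beyond the scatter), towards weaker inhibition. For compound 4 the expected value is 8000 nM, with an estimated range of 2500 nM to 28000 nM.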

Compound 4, half-maximal inhibitory concentration: 1670 nM
For compound 4 the middle estimate is 4.8-fold (0.68 log units) above the measured one; measured number outside the range, below it.
By their numbers in this assay, from the lowest: compounds 4, 1 and 3 (each within the scatter of the next, the first and the last beyond it). At a limit, above all of these: compound 2.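

This position tolerates a five-membered aromatic ring: 1-methyl-1H-pyrazol-5-yl gives a 2.3-fold lower number from compound 3 to compound 4 (0.37 log units; beyond the scatter), so ring size alone does not carry the loss seen with furan-2-yl. It also stands level with pyridin-4-yl, a 1.7-fold lower number from compound 1 to compound 4 (0.24 log units; within the scatter), while the step from furan-2-yl is large, an at least 17-fold lower number from compound 2 to compound 4 (1.25 log units; beyond the scatter). That last step is read against a limit, not a number: the limit of > 30000 nM in this assay, at which 1 of the 4 values shown sits.

Still open, as far as these compounds go, is what the methyl group of 1-methyl-1H-pyrazol-5-yl contributes. Also open, from the compounds shown here alone, is whether an amine or a carboxylic acid on this five-membered ring would shift the number further.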